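The source may hold more compounds than are shown below. What is called first, only, known or untested is meant among the compounds shown, and "the series" means these compounds.

Four compounds share a stilbene-like core in which two benzene rings are joined by a two-carbon double bond, one ring carrying a hydroxyl group. Compound 1 `Nc1ccccc1/C=C/c1cccc(O)c1` carries an amino group on the other ring, and compound 2 `COc1ccccc1/C=C/c1cccc(O)c1` carries a methoxy group in its place. In a functional assay on MCF7 cells (Homo sapiens) for inhibition, read by MTT assay, with a stated time of 2 days (a lower number here means a stronger inhibitor, a higher number a weaker inhibitor), compound 1 gives 17 ug/mL, and compound 2 gives 24.3 ug/mL. The change is methoxy in place of amino on an aromatic carbon, and it made a 1.4-fold higher number from compound 1 to compound 2 (0.16 log units; within the scatter).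

Compound 3 `Nc1ccc(/C=C/c2cccc(O)c2)cc1` is built from the same atoms as compound 1, joined differently; how the two cores differ is not broken down here. In this assay compound 3 gives 24.8 ug/mL, which sits within the usual scatter of both compound 1 and compound 2.

Compound 4 `COc1ccc(/C=C/c2cccc(O)c2)cc1` has not yet been measured. It differs from compound 3 by methoxy in place of amino on an aromatic carbon. Within the data shown here, this is the same kind of change as the one from compound 1 to compound 2, though not the same: there the methoxy sits ortho to a group of 9 heavy atoms, here it sits para to a group of 9 heavy atoms. From compound 3 to compound 4 the step expected in this assay is a 1.3-fold higher number from compound 3 to compound 4 (0.11 log units; within the scatter), resting on the earlier step of a 1.4-fold higher number from compound 1 to compound 2 (0.16 log units; within the scatter), which was small. Compound 4 is therefore estimated at 32 ug/mL, with a plausible range from 17 ug/mL to 60 ug/mL.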

Compound 4, half-maximal inhibitory concentration: 21 ug/mL
Estimate against measurement, compound 4: 1.5-fold (0.18 log units) above; low and high end bracket the measured number.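

Putting methoxy in place of amino on the core of compound 3 gave, in this assay, a 1.2-fold lower number from compound 3 to compound 4 (0.07 log units; within the scatter), so this step is too small to separate from the ordinary spread of repeated measurements. Set beside the earlier case of the same change, the two results show no real disagreement: the same change on two cores in this assay, a 1.4-fold higher number (0.16 log units; within the scatter) from compound 1 to compound 2 and a 1.2-fold lower number (0.07 log units; within the scatter) from compound 3 to compound 4, 1.7-fold (0.23 log units) apart, within the scatter of two such steps. Among these compounds, this shows that, on these two cores, the swap of amino for methoxy gives no step that stands clear of the scatter, and that the gap between the two steps also stays inside it; it does not show that the swap has no effect at all, that the two steps are truly equal, or that the same would hold on any further core.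

The compounds shown leave open what happens when something quite different takes the same place, such as a carboxylic acid, a nitrile or a longer chain like butoxy, any of which might give a step large enough to read clearly. They also leave open what this assay would report for a core without the hydroxyl group that all four compounds share.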